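Swapping benzyl for isopropyl on the core of compound 1

The compounds below may be only part of what the source reports. "The series", "measured", "known", "first", "only" and "open" are said of these compounds alone.

Measured so far:
compound 1 `Nc1ccccc1NC(=O)c1ccc(CNc2nc(Cl)nc3c2ncn3Cc2ccccc2)cc1`: 5.32%
compound 2 `CCCCn1cnc2c(Nc3cccc(Cl)c3)nc(NCOCc3ccc(/C=C/C(=O)Nc4ccccc4N)cc3)nc21`: 30.4%
compound 3 `Nc1ccccc1NC(=O)c1ccc(Cn2cnc3c(NCc4ccccc4)nc(Cl)nc32)cc1`: 62.8%

In a functional assay on HepG2 cells (Homo sapiens) for antiproliferative activity, read by CCK-8 assay, with a stated time of 72 h, tested at 8 uM (on this read-out lower numbers stand for a weaker effect and higher numbers for a stronger effect at the one concentration tested), compound 1 gives 5.32%, the lowest of the three numbers. Compound 2, with 30.4%, lies beyond the scatter above it, and compound 3, with 62.8%, lies beyond the scatter further still. Compound 4 `CC(C)n1cnc2c(NCc3ccc(C(=O)Nc4ccccc4N)cc3)nc(Cl)nc21` has not yet been tested in this assay. It differs from compound 1 in one place: isopropyl in place of benzyl on an aromatic nitrogen. Among the compounds with values here, no pair of measured compounds shows this change on its own, and compound 2 and compound 3 differ from compound 1 in more than one place, so their numbers cannot be read as a guide to the step. Given only the low reading of compound 1 at 5.32%, the step from compound 1 to compound 4 is expected to be small, and its direction is uncertain; a modest rise is estimated as a number 6.7 percentage points higher from compound 1 to compound 4 (within the scatter). Compound 4 is therefore expected to give about 12% in this assay, with a range from 0% to 40%.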

Compound 4, a percentage reported as inhibition, at one concentration (the size of the read-out at that concentration, not a potency): 74.4%
Compound 4: middle estimate off by 62.4 percentage points, on the low side; measured number outside the range, above it.
By their numbers in this assay, from the lowest: compound 1; then compound 2; then compound 3; then compound 4.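

Replacing benzyl with isopropyl on the aromatic nitrogen of the five-membered aromatic ring gives a number 69.1 percentage points higher from compound 1 to compound 4 (beyond the scatter) in this assay. This first one-place step in the set shows that the group on this nitrogen can, on its own, decide much of the read-out, and that here a group with no ring reads far higher than one carrying a six-membered aromatic ring of carbon only. No measurement at hand accounts for the size of this step.

The compounds shown leave open whether the rise follows the loss of the ring or the smaller group, since only these two groups can be compared at this position. A cyclopentyl group, an ethyl group or a longer chain on the same nitrogen would help separate those two readings.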